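Sulfonyl substituent swap from compound 3 to compound 4

A few compounds are considered here, and "the series" means these few. Any claim that something is new, unique, unknown or untested is made for them only; others in the source may bear on it.

In an ADME assay on Caco-2 cells (Homo sapiens) for permeability, read by LC-MS, in the apical to basolateral direction, with a stated time of 2 h, tested at 10 uM (a lower number here means that the compound crosses the layer more slowly, a higher number that the compound crosses the layer faster), compound 3 (`Cn1cnc(S(=O)(=O)N2CCS[C@H]2C(=O)O[C@@H](Cc2c(Cl)c[n+]([O-])cc2Cl)c2ccc(OC(F)F)c(OCC3CC3)c2)c1`) gives 2.2 nm/s, the lowest of the three numbers available. Compound 2 (`COc1ccc(S(=O)(=O)N2CCC[C@H]2C(=O)O[C@@H](Cc2c(Cl)c[n+]([O-])cc2Cl)c2ccc(OC(F)F)c(OCC3CC3)c2)cc1C(=O)N(C)C`) gives 5 nm/s, and compound 1 (`CNC(=O)c1cc(S(=O)(=O)N2CCS[C@H]2C(=O)O[C@@H](Cc2c(Cl)c[n+]([O-])cc2Cl)c2ccc(OC(F)F)c(OCC3CC3)c2)cn1C`) gives 12.6 nm/s.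

The next comparison is compound 4 (`COc1ccc(S(=O)(=O)N2CCS[C@H]2C(=O)O[C@@H](Cc2c(Cl)c[n+]([O-])cc2Cl)c2ccc(OC(F)F)c(OCC3CC3)c2)cc1OC`), described by 3,4-dimethoxyphenyl in place of 1-methyl-1H-imidazol-4-yl on a sulfonyl sulfur. Among the measured compounds shown here, no measured compound carries 3,4-dimethoxyphenyl, so the change has no direct precedent.

For the measured compounds named here, the one measured step at this place is a 5.7-fold lower number from compound 1 to compound 3 (0.76 log units; beyond the scatter), which is beyond the scatter and ends at 1-methyl-1H-imidazol-4-yl. It shows that a change on the sulfonyl sulfur can move this assay by a modest amount. Compound 2 also has a six-membered aromatic ring of carbon only on the sulfonyl sulfur and gives 5 nm/s, but it differs from compound 4 elsewhere too, so it is only a loose guide.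

With compound 3 at the bottom of the measured numbers, an upward move of similar or smaller size is expected. The expected step is a 3.6-fold higher number from compound 3 to compound 4 (0.56 log units; beyond the scatter). For compound 4 the estimated value is 8 nm/s, with an expected range of 3 nm/s to 22 nm/s.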

Compound 4, apparent permeability: 2.5 nm/s
For compound 4 the middle estimate is 3.2-fold (0.51 log units) above the measured one, outside the stated range (below it).
By their numbers in this assay, from the lowest: compounds 3, 4 and 2 (each within the scatter of the next, the first and the last beyond it); then compound 1.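

In this assay the replacement on the sulfonyl sulfur gives a 1.1-fold higher number from compound 3 to compound 4 (0.06 log units; within the scatter), so a group of 10 heavy atoms with a six-membered aromatic ring of carbon only reads the same here as a group of 6 heavy atoms with a five-membered aromatic ring with 2 hetero atoms. The group of compound 1 now stands apart from both, with a 5.0-fold lower number from compound 1 to compound 4 (0.70 log units; beyond the scatter) alongside the earlier 5.7-fold lower number from compound 1 to compound 3 (0.76 log units; beyond the scatter), and since compound 1 and compound 4 both carry 10 heavy atoms in this group yet lie beyond the scatter of each other, the count of heavy atoms alone does not sort these three compounds. No measurement at hand accounts for this ordering.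

The compounds shown leave open whether the higher number of compound 1 goes with its five-membered aromatic ring with 1 hetero atom or with another part of that group. They also leave open how an aromatic ring on the sulfonyl sulfur would read with an aminomethyl group or a carboxylic acid in place of the methoxy groups of compound 4.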